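From an aminoethyl chain to a fluorobenzyl arm

This account rests on a few compounds, and the source may have more. Where it says the series, first, only, none or still open, it means among the compounds named here.

Compound 1 `NCCNc1c(C(=O)NCc2ccc(F)cc2)nc(Br)c2cccnc12` carries a 2-aminoethyl chain on the nitrogen of the shared core. In a functional assay on HCT-116 cells (Homo sapiens) for cytotoxicity, read by MTT assay, with a stated time of 72 h (on this read-out lower numbers stand for stronger inhibition and higher numbers for weaker inhibition), compound 1 gives only a limit of the assay, > 20000 nM. The related compound 2 `N[C@H]1CC[C@H](Nc2c(C(=O)NCc3ccc(Cl)cc3Cl)nc(Br)c3cccnc23)CC1` gives 6000 nM in this assay, and compound 3 `N[C@H]1CC[C@H](Nc2c(C(=O)NCc3ccccc3)nc(Br)c3cccnc23)CC1` gives 7000 nM; the step of a 1.2-fold higher number from compound 2 to compound 3 (0.07 log units; within the scatter) lies within the scatter and concerns the amide side rather than the position changed here. Compound 4 `O=C(NCc1ccc(F)cc1)c1nc(Br)c2cccnc2c1NCc1ccc(F)cc1` differs from compound 1 by 4-fluorophenyl in place of aminomethyl on a saturated chain carbon bound to a nitrogen on an aromatic ring. No measured step touches this position, so the direction of the change cannot be read from the shown compounds; the only anchor is that compound 1 sits at the limit of > 20000 nM in this assay, at which 1 of the 3 values shown sits. Compound 4 is therefore expected to stay weak, with an estimated 15000 nM (range 4000 nM to 50000 nM), an expected step of an at least 1.3-fold lower number from compound 1 to compound 4 (0.12 log units; that floor lies within the scatter).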

Compound 4, half-maximal inhibitory concentration: > 20000 nM
Compound 4: no number, only a limit (the forecaster's own chance of this, stated with the estimate: 50%); middle value at least 1.3-fold (0.12 log units) from the limit.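

Among the compounds shown here, compound 4 gives only a limit of the assay, > 20000 nM, as compound 1 does, so no step between them can be read. The compounds shown leave open how the 2-aminoethyl and 4-fluorobenzyl arms compare.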